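From methylamino to dimethylamino: the step to compound 4

This account rests on a few compounds, and the source may have more. Where it says the series, first, only, none or still open, it means among the compounds named here.

For the measured compounds named here, in a functional assay on HCT-116 cells (Homo sapiens) for antiproliferative activity, read by MTT assay, with a stated time of 48 h (on this read-out higher numbers stand for weaker inhibition and lower numbers for stronger inhibition), compound 3 (`CCCCCCCC(CCO)n1cnc2c(NC)ncnc21`) gives 12500 nM, the only actual number among the three results. Compound 1 (`CCCCCC(CCO)n1cnc2c(N(C)C)ncnc21`) reads > 50000 nM, which is a limit. Compound 2 (`CCCCCCC(CCO)n1cnc2c(N(C)C)ncnc21`) reads > 50000 nM, also a limit. Going by the values given here, the one measured step, a step that the two limits leave unreadable from compound 1 to compound 2, therefore offers no size to borrow. Compound 4 (`CCCCCCCC(CCO)n1cnc2c(N(C)C)ncnc21`) has methyl in place of hydrogen on a nitrogen on an aromatic ring, methylamino to dimethylamino: methyl in place of hydrogen on a nitrogen on an aromatic ring. Compound 1 and compound 2 already carry dimethylamino on shorter chains and rest at the limit of > 50000 nM in this assay, at which 2 of the 3 values shown sit, so a moderate weakening in this assay is expected. The estimated change is a 1.6-fold higher number from compound 3 to compound 4 (0.20 log units; within the scatter). Compound 4 is expected at 20000 nM, with an estimated range of 7000 nM to 50000 nM.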

Compound 4, half-maximal inhibitory concentration: > 50000 nM
Compound 4 gave a limit, no number; the forecaster's own chance of this, stated with the estimate: 25%; middle value at least 2.5-fold (0.39 log units) away from the limit.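

In this assay, for the compounds shown here, methylamino to dimethylamino with the chain unchanged gives an at least 4.0-fold higher number from compound 3 to compound 4 (0.60 log units; beyond the scatter), the first readable step at this nitrogen, and in this pair the added methyl costs activity. Compound 4 is a limit and sits with the two dimethylamino compounds with shorter chains: the limit of > 50000 nM in this assay, at which 3 of the 4 values shown sit. The steps among these three cannot be read, so they say nothing about chain length. On these data alone, it remains open whether a plain amino or an ethylamino group at this nitrogen would match compound 3, and whether a longer chain would bring a dimethylamino compound to a measurable number.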